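This account rests on a few compounds, and the source may have more. Where it says the series, first, only, none or still open, it means among the compounds named here.

In a functional assay on COLO 205 cells (Homo sapiens) for cytotoxicity (on this read-out higher numbers stand for weaker inhibition and lower numbers for stronger inhibition), compound 1 `COc1ccc(Cn2nc(Nc3cc(C)[nH]n3)c3ccccc3c2=O)cc1` gives 4200 nM, compound 2 `Cc1cc(Nc2nn(Cc3ccc(S(C)(=O)=O)cc3)c(=O)c3ccccc23)n[nH]1` gives 4500 nM and compound 3 `Cc1cc(Nc2nn(Cc3cc(F)ccc3F)c(=O)c3ccccc23)n[nH]1` gives 3800 nM, so compound 3 stands within the scatter of the other two. Compound 4 `Cc1cc(Nc2nn(Cc3ccncc3)c(=O)c3ccccc23)n[nH]1` departs from compound 3 by one change: pyridin-4-yl in place of 2,5-difluorophenyl on a saturated chain carbon bound to an aromatic nitrogen. For the measured compounds named here, two measured steps bear on it: a 1.1-fold higher number from compound 1 to compound 2 (0.03 log units; within the scatter) and a 1.1-fold lower number from compound 1 to compound 3 (0.04 log units; within the scatter). Neither goes beyond the scatter, though neither tests a ring with a hetero atom in this place. The expected step in this assay is a 1.2-fold higher number from compound 3 to compound 4 (0.07 log units; within the scatter), none beyond the scatter. Compound 4 is estimated at 4500 nM, with an expected range of 2000 nM to 10000 nM.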

Compound 4, half-maximal inhibitory concentration: 13000 nM
Compound 4: the middle estimate sits 2.9-fold (0.46 log units) below what was measured; measured number above the stated range.
By their numbers in this assay, from the lowest: compounds 3, 1 and 2 (each within the scatter of the next); then compound 4.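

At the saturated chain carbon bound to an aromatic nitrogen, earlier changes had moved nothing beyond the scatter, but pyridin-4-yl gives a 3.4-fold higher number from compound 3 to compound 4 (0.53 log units; beyond the scatter) and a 3.1-fold higher number from compound 1 to compound 4 (0.49 log units; beyond the scatter) in this assay. This place is therefore not indifferent to the group it carries, and a ring with a hetero atom separates from both 2,5-difluorophenyl and 4-methoxyphenyl. No measurement shown gives a reason for this shift. The compounds shown leave open whether the step follows the ring nitrogen or the loss of the ring's substituents, which an unsubstituted phenyl would help to separate. On these data alone, whether pyridin-3-yl would behave like pyridin-4-yl also stays open.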